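Removing a Bromo Group: Expected Effect on Cytotoxicity

The compounds below may be only part of what the source reports. "The series", "measured", "known", "first", "only" and "open" are said of these compounds alone.

Measured compounds:
compound 1, `O=C1N(Cc2ccccc2Cl)c2cccn2S(=O)(=O)N1Cc1cccc(Br)c1`: > 260000 nM
compound 2, `O=C1N(Cc2cccc(Cl)c2)c2cccn2S(=O)(=O)N1Cc1cccc(F)c1`: 208000 nM
compound 3, `N#CCN1C(=O)N(Cc2ccccc2)S(=O)(=O)c2cscc21`: 503000 nM

All three values come from an ADME assay on MT4 cells (Homo sapiens) for cytotoxicity, read by MTT assay, with a stated time of 5 days; on this read-out lower numbers stand for higher toxicity in this test and higher numbers for lower toxicity in this test. Compound 1 gives > 260000 nM in this assay, and this is a limit of the assay rather than a number; it is described by the limit of > 260000 nM in this assay, at which 1 of the 3 values shown sits. Compound 2 gives 208000 nM in this assay. Compound 3 gives 503000 nM in this assay. None of the three reaches a strongly toxic reading on this scale.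

Compound 4, `O=C1N(Cc2ccccc2Cl)c2cccn2S(=O)(=O)N1Cc1ccccc1`, has not yet been measured. It differs from compound 1 in one place: hydrogen in place of bromo on an aromatic carbon. Cut one bond further out, the change reads 3-bromobenzyl to benzyl. Among the measured compounds shown here, no two of the measured compounds differ in a single place, so no measured step shows what such a change does here. Because compound 1 stands at the limit (the limit of > 260000 nM in this assay, at which 1 of the 3 values shown sits), only a move toward stronger toxicity could be seen in this assay, and no such move is suggested by the other two readings.

The expected step is an at least 1.0-fold lower number from compound 1 to compound 4 (0.01 log units; that floor lies within the scatter), taken to lie within the usual scatter. Compound 4 is therefore estimated at 250000 nM in this assay, between 120000 nM and 500000 nM, with a fair chance that again only a limit is reported.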

Compound 4, half-maximal cytotoxic concentration: > 291000 nM
Compound 4 was reported as a limit; the forecaster's own chance of this, stated with the estimate: 50%; at least 1.1-fold (0.06 log units) between middle value and limit.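

In this assay, compound 1 and compound 4 are each reported only as a limit, so no step can be read between them. Compound 1 is given as a limit: the limit of > 260000 nM in this assay, at which 1 of the 4 values shown sits.

Compound 4 is also given as a limit: the limit of > 291000 nM in this assay, at which 1 of the 4 values shown sits.

The compounds shown leave open whether replacing the bromo group with hydrogen changes the cytotoxicity reading at all.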